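Propargyloxy in place of a sulfanyl side chain on compound 1

A few compounds are considered here, and "the series" means these few. Any claim that something is new, unique, unknown or untested is made for them only; others in the source may bear on it.

compound 1 `COC(=O)CSc1cc(/N=c2\sc(=S)n3n2CCCC3)c(F)cc1Cl` — 191 nM
compound 2 `S=c1n(-c2ccccc2)c(=S)n2n1CCCC2` — 6310 nM
compound 3 `S=c1s/c(=N\c2ccc(OCc3ccc(Cl)cc3)cc2)n2n1CCCC2` — 20 nM

In a functional assay on the whole organism with Scenedesmus acutus as the target, read by spectrophotometry (on this read-out lower numbers stand for stronger inhibition and higher numbers for weaker inhibition), compound 1 gives 191 nM, the second highest of the three numbers. Compound 3 gives 20 nM, a lower number that lies beyond the scatter, and compound 2 gives 6310 nM, a higher number also beyond the scatter. Compound 4 `C#CCOc1cc(/N=c2\sc(=S)n3n2CCCC3)c(F)cc1Cl` is not yet measured and differs from compound 1 in one place: propargyloxy in place of ((methoxycarbonyl)methyl)sulfanyl on an aromatic carbon. Going by the values given here, no measured pair of compounds shows this change, so the data give no direct step for it. The expected step of a 1.5-fold lower number from compound 1 to compound 4 (0.17 log units; within the scatter) is therefore toward a lower number but of a size that remains within the usual scatter. Compound 4 is estimated at 130 nM, with a range from 40 nM to 420 nM.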

Compound 4, half-maximal inhibitory concentration: 5.5 nM
For compound 4 the middle estimate is 24-fold (1.37 log units) above the measured one; measured number below the stated range.
By their numbers in this assay, from the lowest: compound 4; then compound 3; then compound 1; then compound 2.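

With the rest of compound 1 unchanged, exchanging ((methoxycarbonyl)methyl)sulfanyl for propargyloxy gives a 35-fold lower number from compound 1 to compound 4 (1.54 log units; beyond the scatter) in this assay and is the first one-place change shown here. The group on this aromatic carbon, ortho to a chloro group and para to a fluoro group, can therefore shift the inhibition read-out strongly by itself. No evidence here explains the size of this step. On these data alone, it remains open whether the ether oxygen or the triple bond carries the step. A propargylsulfanyl group, a propyloxy chain or an amine at this place would separate the two.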